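A few compounds are considered here, and "the series" means these few. Any claim that something is new, unique, unknown or untested is made for them only; others in the source may bear on it.

Measured so far in a functional assay on ileum for inhibition of histamine H1 receptor (Cavia porcellus); a lower number here means a stronger inhibitor, a higher number a weaker inhibitor: compound 1 `CN1CCN(c2nc3ccccc3n2CCO)CC1` gives 410 nM; compound 2 `CCCCOCCn1c(N2CCN(C)CC2)nc2ccccc21` gives 38 nM; compound 3 `CCCSCn1c(N2CCN(C)CC2)nc2ccccc21` gives 68 nM.

Compound 3 holds the second highest of these three numbers. Its nearest neighbour is compound 2, and the step of a 1.8-fold higher number from compound 2 to compound 3 (0.25 log units; within the scatter) lies within the scatter; the step of a 6.0-fold lower number from compound 1 to compound 3 (0.78 log units; beyond the scatter) is beyond it. Compound 4 `CCSCCn1c(N2CCN(C)CC2)nc2ccccc21` has not been measured. It differs from compound 3 in one place: (ethylsulfanyl)methyl in place of propylsulfanyl on a saturated chain carbon bound to an aromatic nitrogen. The step that bears on this change is a 1.8-fold higher number from compound 2 to compound 3 (0.25 log units; within the scatter), where one chain replaced another of similar size without a shift beyond the scatter. The large steps of an 11-fold lower number from compound 1 to compound 2 (1.03 log units; beyond the scatter) and a 6.0-fold lower number from compound 1 to compound 3 (0.78 log units; beyond the scatter) concern compound 1 and are not the relevant comparison. For compound 4 the expected step of a 1.1-fold lower number from compound 3 to compound 4 (0.05 log units; within the scatter) is therefore none beyond the scatter. Compound 4 is thus estimated at 60 nM, ranging from 25 nM to 150 nM.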

Compound 4, half-maximal inhibitory concentration: 19 nM
Estimate against measurement, compound 4: 3.2-fold (0.50 log units) above; the whole stated range lies above it.
By their numbers in this assay, from the lowest: compounds 4, 2 and 3 (each within the scatter of the next, the first and the last beyond it); then compound 1.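

In this assay the same atoms joined differently give a 3.6-fold lower number from compound 3 to compound 4 (0.55 log units; beyond the scatter) and so, at this position on the chain, the arrangement of the atoms matters and not only their number. Ethylsulfanyl in place of butoxy gives a 2.0-fold lower number from compound 2 to compound 4 (0.30 log units; within the scatter) and stays within the scatter, while ethylsulfanyl in place of hydroxy gives a 22-fold lower number from compound 1 to compound 4 (1.33 log units; beyond the scatter) as the largest step here. No measurement shown explains why the rearranged chain differs in this way.

Still open, going by these compounds, is whether a longer chain, such as 2-(propylsulfanyl)ethyl, would hold this level. An amine in place of the ethylsulfanyl is also untested among the compounds shown.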